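Working notes: bromo in place of hydrogen on compound 1

The source may hold more compounds than are shown below. What is called first, only, known or untested is meant among the compounds shown, and "the series" means these compounds.

compound 1 `O=C1NC(=O)/C(=C/c2cn(Cc3ccccc3)c3ccccc23)N1` gives 15700 nM
compound 2 `COC(=O)c1ccc(Cn2cc(/C=C3\NC(=O)NC3=O)c3ccccc32)cc1` gives 18400 nM
compound 3 `O=C1NC(=O)/C(=C/c2cn(Cc3ccccc3Br)c3ccccc23)N1` gives 21800 nM

In a functional assay on MDA-MB-231 cells (Homo sapiens) for antiproliferative activity, read by trypan blue exclusion, with a stated time of 24 h (on this read-out lower numbers stand for stronger inhibition and higher numbers for weaker inhibition), compound 1 stands together with the other two compounds, since neither of its steps leaves the scatter. The nearest is a 1.2-fold higher number from compound 1 to compound 2 (0.07 log units; within the scatter) and the furthest is a 1.4-fold higher number from compound 1 to compound 3 (0.14 log units; within the scatter). The next compound to be measured, compound 4 `O=C1NC(=O)/C(=C/c2cn(Cc3ccccc3)c3ccc(Br)cc23)N1`, carries a single change on the core of compound 1, namely (bromo in place of hydrogen on an aromatic carbon). In words, this is bromo in place of hydrogen on an aromatic carbon.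

The closest evidence is a 1.4-fold higher number from compound 1 to compound 3 (0.14 log units; within the scatter), the same exchange made on a different ring. The methoxycarbonyl change gives a 1.2-fold higher number from compound 1 to compound 2 (0.07 log units; within the scatter) and bears on it less directly. Going by the values given here, no compound yet tests any substitution on the ring that changes in compound 4, so the transfer is uncertain. No step beyond the scatter is expected in this assay. The expected step is a 1.1-fold higher number from compound 1 to compound 4 (0.03 log units; within the scatter). For compound 4 the estimated value is 17000 nM, with an expected range from 8500 nM to 34000 nM.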

Compound 4, half-maximal inhibitory concentration: 12400 nM
Estimate against measurement, compound 4: 1.4-fold (0.14 log units) above; the range from low to high includes it.
By their numbers in this assay, from the lowest: compounds 4, 1, 2 and 3 (each within the scatter of the next).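

In this assay, bromo on an aromatic carbon of the six-membered aromatic ring of carbon only, meta to a fused ring and para to a fused ring, gives a 1.3-fold lower number from compound 1 to compound 4 (0.10 log units; within the scatter), so this position accepts the bromine without a step beyond the scatter. This is the only substitution shown on this ring, and the outcome matches the same exchange on the other ring, where a 1.4-fold higher number from compound 1 to compound 3 (0.14 log units; within the scatter) also stays inside the scatter. No measured evidence accounts for either step.

With a single bromo at this place, the compounds shown leave open whether any substituent here can move the number beyond the scatter. An amine, a carboxylic acid or methoxycarbonyl at this position would test that, since bromo alone gives no trend across groups.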